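Acylguanidine sodium/hydrogen exchanger inhibitors: imidazolyl replaces benzyloxy

The compounds below may be only part of what the source reports. "The series", "measured", "known", "first", "only" and "open" are said of these compounds alone.

Measured compounds:
compound 1, `Cc1cc(Sc2ccccc2Cl)c(S(C)(=O)=O)cc1C(=O)N=C(N)N`, 14 nM
compound 2, `Cc1cc(OCc2ccccc2)c(S(C)(=O)=O)cc1C(=O)N=C(N)N`, 28 nM

In a functional assay for inhibition of sodium/hydrogen exchanger (Oryctolagus cuniculus) (on this read-out higher numbers stand for weaker inhibition and lower numbers for stronger inhibition), compound 1 gives 14 nM and compound 2 gives 28 nM. Among the compounds with values here, the only step between measured compounds, a 2.0-fold higher number from compound 1 to compound 2 (0.30 log units; within the scatter), is within the scatter, so compound 2 and compound 1 cannot be told apart on these numbers. Compound 2 holds the highest of the two numbers, and compound 1 is nearest to it.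

Compound 3, `Cc1cc(-n2ccnc2)c(S(C)(=O)=O)cc1C(=O)N=C(N)N`, is not yet measured. It differs from compound 2 in one place: 1H-imidazol-1-yl in place of benzyloxy on an aromatic carbon. Within the data shown here, the only measured step, that from compound 1 to compound 2, exchanges one group on this same aromatic carbon for another and is within the scatter, which suggests that this position may tolerate a change of substituent. The group entering compound 3 is, however, smaller and of a different kind than either group seen so far, so the measured step gives only weak guidance. Compound 3 is expected to give 45 nM in this assay, within a range of 12 nM to 180 nM. The expected step is a 1.6-fold higher number from compound 2 to compound 3 (0.21 log units; within the scatter), an estimate that leans toward a somewhat higher number while remaining close to the scatter.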

Compound 3, half-maximal inhibitory concentration: 23 nM
Beside the measured number, compound 3's estimate is 2.0-fold (0.29 log units) above it; measured number inside the range.
By their numbers in this assay, from the lowest: compounds 1, 3 and 2 (each within the scatter of the next).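

In this assay, 1H-imidazol-1-yl in place of benzyloxy gives a 1.2-fold lower number from compound 2 to compound 3 (0.09 log units; within the scatter), and the same group in place of (2-chlorophenyl)sulfanyl gives a 1.6-fold higher number from compound 1 to compound 3 (0.22 log units; within the scatter). The earlier compounds had shown only two groups on this aromatic carbon, ortho to a methylsulfonyl group, each carrying a six-membered aromatic ring of carbon only; compound 3 adds a five-membered aromatic ring with 2 hetero atoms, and the three compounds still cannot be told apart in this read-out, so here the change in ring and in heavy-atom count, from 8 to 5 against benzyloxy, comes with no step beyond the scatter. No measurement at hand explains why these three groups read alike.

The compounds shown leave open whether this position would stay within the scatter with a group lacking an aromatic ring altogether, such as an amine, a carboxylic acid or a longer alkyl chain. They also leave open whether the imidazolyl compound would keep its reading if the methyl or the methylsulfonyl group on the shared core were exchanged for another group.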